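Fluorocyclopropyl amide on the diazabicyclic core: an expected value

The compounds below may be only part of what the source reports. "The series", "measured", "known", "first", "only" and "open" are said of these compounds alone.

Measured compounds:
Compound 1, `CCC(=O)N1CC2CC(C1)N2`: 6 nM
Compound 2, `O=C(C1CCCC1)N1CC2CC(C1)N2`: 160 nM

Of the compounds shown here, two have been measured in an assay on SH-EP1 cells for displacement of a labelled ligand from Neuronal acetylcholine receptor; alpha4/beta2 (Homo sapiens), read by scintillation counting; a higher number here means a weaker inhibitor, a lower number a stronger inhibitor. Compound 1 carries a propanoyl group on the shared core and gives 6 nM in this assay, the lowest of the two numbers. Its cyclopentanecarbonyl counterpart, compound 2, gives 160 nM, a higher number whose gap to compound 1 lies beyond the scatter. Among the compounds with values here, no step between compounds differing in a single place is available, so the comparison rests on these two values alone.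

Compound 3, `O=C([C@H]1C[C@H]1F)N1CC2CC(C1)N2`, has not been measured in this assay. It differs from compound 1 in one respect: 2-fluorocyclopropyl in place of ethyl on a carbonyl carbon. The entering group is a three-membered ring, smaller than the five-membered ring of compound 2, and bears a fluorine.

Because compound 1 gives 6 nM while compound 2 gives 160 nM, a ring on the carbonyl carbon is expected to raise the number, but a three-membered ring is expected to do so less than the five-membered one. The step of a 2.5-fold higher number from compound 1 to compound 3 (0.40 log units; beyond the scatter) is therefore expected to be a modest rise, close to the edge of the scatter. Compound 3 is estimated at 15 nM in this assay, with a range from 5 nM to 60 nM.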

Compound 3, inhibition constant: 1.1 nM
Compound 3: the middle estimate sits 14-fold (1.13 log units) above what was measured; measured number outside the range, below it.
By their numbers in this assay, from the lowest: compound 3; then compound 1; then compound 2.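

In this assay, the step from ethyl to 2-fluorocyclopropyl on the carbonyl carbon is a 5.5-fold lower number from compound 1 to compound 3 (0.74 log units; beyond the scatter), so a ring at this place does not in itself bring a higher number. Until now, the only ring at this place was the five-membered ring of compound 2 at 160 nM, a higher number than that of compound 1; with compound 3 the position is seen to move in both directions, depending on the group it carries. No measurement available here bears on what lies behind this difference.

The change brings in a three-membered ring, a fluorine and two defined stereocentres all at once, so the compounds shown leave open which of these accounts for the step; a plain cyclopropyl group on the same carbonyl carbon would separate the ring from the fluorine, and the mirror-image 2-fluorocyclopropyl group would test the stereocentres. Also open, on these data alone, is how the number changes with ring size between the three-membered and five-membered rings, as a cyclobutyl group would show.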